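The source may report more compounds than this note shows. Statements on the series, on what has been measured and on what is new or still open speak of the compounds shown alone.

Compound 1 `Oc1cccc(CNc2ncnc3c2ncn3C2CCCCO2)c1` gives 81000 nM
Compound 2 `COc1cccc(CNc2ncnc3c2ncn3C2CCCCO2)c1O` gives > 100000 nM as a limit

In an ADME assay on K562 cells (Homo sapiens) for cytotoxicity, with a stated time of 72 h (on this read-out higher numbers stand for weaker inhibition and lower numbers for stronger inhibition), compound 2 stands at > 100000 nM and this is a limit of the assay, not a number. Compound 3 `Oc1cccc(CNc2ncnc3c2ncn3C2CCCCO2)c1O` differs from compound 2 in one place, hydrogen in place of methyl on an oxygen on an aromatic ring with hydrogen in place of methyl on an oxygen on an aromatic ring, so methoxy becomes hydroxy. Compound 1 has no methoxy and gives 81000 nM in this assay so a small move towards stronger inhibition is expected. The estimated change is an at least 1.4-fold lower number from compound 2 to compound 3 (0.15 log units; that floor lies within the scatter) and it is expected to be modest. For compound 3 the estimate is 70000 nM with an expected range of 35000 nM to 100000 nM on repeated measurement.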

Compound 3, half-maximal inhibitory concentration: 92000 nM
Compound 3: middle estimate off by 1.3-fold (0.12 log units), on the low side, within the range that was stated.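

Going from methoxy to hydroxy gives an at least 1.0-fold lower number from compound 2 to compound 3 (0.03 log units; that floor lies within the scatter) in this assay. The true size of this step stays unknown because compound 2 gives only a limit of the assay, not a number: the limit of > 100000 nM in this assay, at which 1 of the 3 values shown sits.

Hydroxy in place of hydrogen on an aromatic carbon gives a 1.1-fold higher number from compound 1 to compound 3 (0.06 log units; within the scatter), so this added hydroxy brings no readable change. As far as these compounds go, whether an amine or a carboxylic acid on that aromatic carbon would move the number beyond the scatter stays open. So does the effect of a longer chain, such as ethoxy, in place of methoxy.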